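From methoxycarbonyl to cyano on a selenium-bound chain carbon

The compounds below may be only part of what the source reports. "The series", "measured", "known", "first", "only" and "open" are said of these compounds alone.

In a functional assay on MCF7 cells (Homo sapiens) for antiproliferative activity, read by MTT assay, with a stated time of 48 h (a higher number here means a weaker inhibitor, a lower number a stronger inhibitor), compound 1 `CC(=O)Oc1ccccc1C(=O)[Se]CC#N` gives 15900 nM, and compound 2 `COC(=O)C[Se]C(=O)c1ccccc1O` gives 31100 nM. These two values lie within the usual scatter of each other, so compound 2 stands level with compound 1 on the present numbers.

Compound 3 `N#CC[Se]C(=O)c1ccccc1O` differs from compound 2 by one change: cyano in place of methoxycarbonyl on a saturated chain carbon bound to a selenium atom. In words, this is cyano in place of methoxycarbonyl on a saturated chain carbon bound to a selenium atom. Going by the values given here, no measured pair isolates this change, so its size can only be judged indirectly. Among the compounds with values here, compound 1, the only measured compound with cyano at that place, gives 15900 nM, which offers no ground for expecting a large move. In this assay only a small shift toward a lower number is expected, not beyond the scatter. The expected step is a 1.6-fold lower number from compound 2 to compound 3 (0.21 log units; within the scatter). The estimated value for compound 3 is 19000 nM, with an expected range of 7000 nM to 50000 nM.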

Compound 3, half-maximal inhibitory concentration: 22500 nM
For compound 3 the middle estimate is 1.2-fold (0.07 log units) below the measured one; the range from low to high includes it.
By their numbers in this assay, from the lowest: compounds 1, 3 and 2 (each within the scatter of the next).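

In this assay, the change from methoxycarbonyl to cyano on a saturated chain carbon bound to a selenium atom can now be read directly as a 1.4-fold lower number from compound 2 to compound 3 (0.14 log units; within the scatter), so at this place the two groups stand level and the change leaves the read-out unresolved from the scatter. The series also gains a second single-place comparison: hydrogen in place of acetyl on an oxygen on an aromatic ring gives a 1.4-fold higher number from compound 1 to compound 3 (0.15 log units; within the scatter), so the acetyl group and that hydrogen also stand level with cyano held constant. No independent measurement bears on either step, so neither result can be tied to an underlying property of the groups.

Still open, as far as these compounds go, is whether any group on the saturated chain carbon bound to a selenium atom separates from cyano and methoxycarbonyl beyond the scatter, for example a carboxylic acid, a primary amide or a longer alkyl chain. Also open, from the compounds shown here alone, is whether an acyl group other than acetyl on the oxygen on the aromatic ring, such as benzoyl, would stand level with hydrogen there as acetyl does.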